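Hydroxypiperidinyl carbonyl in place of carboxy: expected solubility of compound 4

A few compounds are considered here, and "the series" means these few. Any claim that something is new, unique, unknown or untested is made for them only; others in the source may bear on it.

In a physicochemical assay for solubility, read by HPLC, using the shake flask method, with a stated time of 2 h, at pH 2 (a higher number here means a more soluble compound, a lower number a less soluble compound), compound 3 `Nc1ncc(-c2ccc(C(=O)O)cc2)nc1-c1ccc(C(F)(F)F)cc1` stands at < 5000 nM which is a limit and not a number. Compound 1 `Nc1ncc(-c2ccc(C(=O)N3CCC(O)C3)cc2)nc1-c1ccc(C(F)(F)F)cc1` gives 129000 nM and compound 2 `Nc1ncc(-c2ccc(C(=O)N3CC[C@H](O)C3)cc2)nc1-c1ccc(C(F)(F)F)cc1` gives 93000 nM in the same measurement. These two read as one level, with a 1.4-fold lower number from compound 1 to compound 2 (0.14 log units; within the scatter) on record. Compound 4 `Nc1ncc(-c2ccc(C(=O)N3CCC(O)CC3)cc2)nc1-c1ccc(C(F)(F)F)cc1` carries 4-hydroxypiperidin-1-yl in place of hydroxy on a carbonyl carbon on the core of compound 3. The nearest steps run the opposite way, with 3-hydroxypyrrolidin-1-yl leaving: an at least 25-fold lower number from compound 1 to compound 3 (1.41 log units; beyond the scatter) and an at least 18-fold lower number from compound 2 to compound 3 (1.26 log units; beyond the scatter) are both large, and both are minimum sizes. A large rise is therefore expected in this assay and the estimated step is an at least 16-fold higher number from compound 3 to compound 4 (1.20 log units; beyond the scatter) on this change. For compound 4 the estimated value is 80000 nM with an expected range from 30000 nM to 200000 nM in this measurement.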

Compound 4, solubility: 119000 nM
Compound 4: the middle estimate sits 1.5-fold (0.17 log units) below what was measured; the measured number falls inside the stated range.
By their numbers in this assay, from the lowest: compounds 2, 4 and 1 (each within the scatter of the next). At a limit, below all of these: compound 3.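

In this assay, going by these compounds alone, 4-hydroxypiperidin-1-yl on the carbonyl carbon gives a large step of the kind so far seen only with 3-hydroxypyrrolidin-1-yl: an at least 23-fold higher number from compound 3 to compound 4 (1.37 log units; beyond the scatter). That step is a minimum size because compound 3 stands at a limit and not a number: the limit of < 5000 nM in this assay, at which 1 of the 4 values shown sits. The two amide groups read as one level, with a 1.3-fold higher number from compound 2 to compound 4 (0.11 log units; within the scatter) and a 1.1-fold lower number from compound 1 to compound 4 (0.04 log units; within the scatter), so the change of group at this position separates nothing here.

As far as these compounds go, whether this level needs the ring hydroxy remains open. Plain piperidin-1-yl, or an amine such as 4-aminopiperidin-1-yl, would test that.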